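The source may report more compounds than this note shows. Statements on the series, on what has been measured and on what is new or still open speak of the compounds shown alone.

Measured so far:
- compound 1 `Cc1ccncc1-c1cccc2c1cnn2-c1cccnn1`: 89%
- compound 2 `Cc1ccncc1-c1cccc2c1ncn2-c1cnccn1`: 98%

In an ADME assay on liver for metabolic stability, with Liver microsome (Homo sapiens) as the target, using microsomes, with a stated time of 10 min, tested at 0.5 uM (on this read-out higher numbers stand for a more stable compound and lower numbers for a less stable compound), compound 1 gives 89%, which lies within the usual scatter of compound 2 at 98%. The two compounds therefore cannot be told apart on this read-out, and both sit high on the scale.

The next compound to be measured is compound 3 `Cc1ccncc1-c1cccc2c1cnn2-c1ccc(F)cc1`. It keeps the core of compound 1 and carries 4-fluorophenyl in place of pyridazin-3-yl on an aromatic nitrogen. The new group brings one six-membered aromatic ring of carbon only.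

Among the compounds with values here, no pair of measured compounds differing in one place is available, so the size of this step has no direct precedent. Neither measured compound carries 4-fluorophenyl, which leaves the expectation loose. A moderate fall is expected rather than a flat result, and the high level of compound 1 at 89% leaves little room for a rise. The expected change is estimated as a number 14 percentage points lower from compound 1 to compound 3 (beyond the scatter). For compound 3 the estimated value in this assay is 75%, with an expected range of 55% to 92%.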

Compound 3, percent of the compound remaining: 100%
Compound 3: the middle estimate sits 25 percentage points below what was measured, and the stated range ends below it.
By their numbers in this assay, from the lowest: compounds 1, 2 and 3 (each within the scatter of the next, the first and the last beyond it).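

At the position on an aromatic nitrogen of a five-membered aromatic ring, this assay now offers its first readable step: with the core of compound 1 held constant, 4-fluorophenyl in place of pyridazin-3-yl gives a number 11 percentage points higher from compound 1 to compound 3 (beyond the scatter). The position therefore accepts a six-membered aromatic ring of carbon only in place of one with 2 hetero atoms, and compound 3 stands at 100%, so the change brings no loss on this read-out. This single step shows what happens for one exchange of groups, but no measurement shown bears on why the read-out moves with it.

Going by these compounds, whether 4-fluorophenyl has a similar effect on the core of compound 2 remains open, as does the response of this position to a group of another kind, such as an aliphatic amine, a carboxylic acid or a morpholine ring. With compound 3 at the top of the scale, this assay at this stated time also leaves little room to show any further rise, so a further change at this position could be read mainly as a fall.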